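Taking the methyl off compound 2: tolerance notes

This account rests on a few compounds, and the source may have more. Where it says the series, first, only, none or still open, it means among the compounds named here.

Measured so far in an ADME assay on HEK-293T cells (Homo sapiens) for cytotoxicity, read by CCK-8 assay, with a stated time of 24 h; a lower number here means that less compound is tolerated, a higher number that more compound is tolerated:
- compound 1 `O=C(CSc1c[nH]c2ccccc12)NCc1ccc(C(F)(F)F)cc1` gives > 100000 nM (a limit)
- compound 2 `C[C@@H](NC(=O)CSc1c[nH]c2ccccc12)c1ccccc1` gives > 100000 nM (a limit)
- compound 3 `COc1ccccc1CNC(=O)CSc1c[nH]c2c(-c3ccccc3)cccc12` gives 95500 nM (a number)

Compound 2 gives > 100000 nM, which is a limit and not a number. Its place on the scale is the limit of > 100000 nM in this assay, at which 2 of the 3 values shown sit, and compound 1 shares that place. For the measured compounds named here, compound 3 is the only one of the three with a number, and no measured step connects it to the other two.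

Compound 4 `O=C(CSc1c[nH]c2ccccc12)NCc1ccccc1` is the next to be read. It differs from compound 2 by hydrogen in place of methyl on a saturated chain carbon bound to an amide-type nitrogen and an aromatic carbon, with hydrogen in place of methyl on a saturated chain carbon bound to an amide-type nitrogen and an aromatic carbon.

Going by the values given here, no step between measured compounds is available to size this change in this assay. The expectation therefore rests on compound 2 and its reading of > 100000 nM, and no direction is favoured. The expected a number no higher from compound 2 to compound 4 (the limit leaves the size open) is none beyond the usual scatter. For compound 4 the estimated value is 100000 nM, with an expected range from 60000 nM to 200000 nM as the likely span, and a report as a limit is the more likely outcome.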

Compound 4, half-maximal cytotoxic concentration: > 100000 nM
Compound 4: no number, only a limit (the forecaster's own chance of this, stated with the estimate: 75%); the middle value sits exactly at the limit.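

In this assay compound 4 gives > 100000 nM, which is a limit and not a number. Compound 1 and compound 2 also stand at limits, so neither the step from compound 2 to compound 4 nor the step from compound 1 to compound 4 can be read. The compounds shown leave open whether methyl or trifluoromethyl changes tolerance at all.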